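Replacing a hydroxymethyl group with a fluorinated phenyl ring

A few compounds are considered here, and "the series" means these few. Any claim that something is new, unique, unknown or untested is made for them only; others in the source may bear on it.

Compound 1 `O=C(Cn1cc(CO)nn1)NCc1ccccc1` was tested in an ADME assay on cells (spleen, Mus musculus, strain C57BL/6) for inhibition, read by flow cytometry and propidium iodide staining, with a stated time of 24 h, at 37 degrees C (a higher number here means that more compound is needed for the effect, a lower number that less compound is needed), where compound 1 gives 490 uM. Within the data shown here, compound 2 `CC(C)(O)c1cn(CC(=O)NCc2ccccc2)nn1` is the only other measured compound, and in this assay compound 2 gives 1600 uM. Among the measured compounds shown here, of the two numbers, compound 1 has the lower one; the single measured step, a 3.3-fold higher number from compound 1 to compound 2 (0.51 log units; beyond the scatter), swaps one small oxygen-bearing group for another. Compound 3 `O=C(Cn1cc(-c2cccc(F)c2)nn1)NCc1ccccc1` is not yet measured. Its difference from compound 1 is 3-fluorophenyl in place of hydroxymethyl on an aromatic carbon. For the measured compounds named here, the one known step bears only loosely on this change, since it keeps a hydroxyl group while the new group in compound 3 carries none, so it offers no direct guide to the direction. With that limited support, a step of modest size at most is expected in this assay for compound 3, with the direction uncertain and most likely within the scatter, which the estimate a 1.6-fold lower number from compound 1 to compound 3 (0.21 log units; within the scatter) reflects. For compound 3 the expected value in this assay is 300 uM, within a range from 80 uM to 1200 uM.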

Compound 3, concentration for half-maximal effect: "non-toxic" (no number reported)
Nothing numeric was reported for compound 3, and the estimate cannot be compared.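

Among these compounds, compound 3 is recorded in this assay only as "non-toxic", without a number, so no step from compound 1 to compound 3 can be read. No measured evidence bears on this result. The compounds shown leave open how far, and in which direction, 3-fluorophenyl in place of hydroxymethyl moves the number.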